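The source may report more compounds than this note shows. Statements on the series, on what has been measured and on what is new or still open speak of the compounds shown alone.

In a functional assay on HepG2 cells (Homo sapiens) for cytotoxicity, read by MTT assay, with a stated time of 48 h (a higher number here means a weaker inhibitor, a lower number a stronger inhibitor), three compounds have been measured so far:

compound 1, `CNC(=O)CSc1nc2ccc(NC(=O)c3ccccc3)cc2s1`: 26500 nM
compound 2, `O=C(CSc1nc2ccc(NC(=O)c3ccccc3)cc2s1)NCc1ccccc1`: 34200 nM
compound 3, `COc1ccc(CNC(=O)CSc2nc3ccc(NC(=O)c4ccccc4)cc3s2)cc1`: 12700 nM

Compound 3 gives the lowest number of the three in this assay. The step from compound 1 to compound 2 is a 1.3-fold higher number from compound 1 to compound 2 (0.11 log units; within the scatter), while a 2.1-fold lower number from compound 1 to compound 3 (0.32 log units; beyond the scatter) and a 2.7-fold lower number from compound 2 to compound 3 (0.43 log units; beyond the scatter) both fall beyond the scatter, so compound 3 stands apart from the other two.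

Compound 4, `COc1ccc(CNC(=O)CSc2nc3ccc(NC(=O)c4ccccc4OC)cc3s2)cc1`, is not yet measured. It differs from compound 3 in one place: methoxy in place of hydrogen on an aromatic carbon. For the measured compounds named here, the only measured step of the same kind is a 2.7-fold lower number from compound 2 to compound 3 (0.43 log units; beyond the scatter), where a methoxy entered on the other aromatic ring, the one bound to the amide nitrogen through a saturated chain carbon. Whether a methoxy ortho to a large group on the benzoyl ring behaves the same way is not shown by the data. A modest lowering, or no step beyond the scatter, is therefore expected. Compound 4 is estimated at 9000 nM, between 3500 nM and 25000 nM, which would mean a 1.4-fold lower number from compound 3 to compound 4 (0.15 log units; within the scatter).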

Compound 4, half-maximal inhibitory concentration: 2100 nM
Beside the measured number, compound 4's estimate is 4.3-fold (0.63 log units) above it, and the stated range ends above it.
By their numbers in this assay, from the lowest: compound 4; then compound 3; then compounds 1 and 2 (each within the scatter of the next).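

In this assay, the benzoyl ring proves to be a place where a single added methoxy counts: as a 2-methoxyphenyl, ortho to a large group, it gives a 6.0-fold lower number from compound 3 to compound 4 (0.78 log units; beyond the scatter). The earlier compounds shown here showed this replacement only on the other aromatic ring, where it gave a 2.7-fold lower number from compound 2 to compound 3 (0.43 log units; beyond the scatter), so compound 4 shows that a lower number beyond the scatter can also be reached from the benzoyl side, and that the two methoxy groups can stand together in one molecule. Nothing in the available evidence accounts for this step.

Going by these compounds, whether a hydroxy group, a chlorine atom or a dimethylamino group at this same place would give a comparable step remains open. Also open, on these data alone, is whether the 2-methoxyphenyl would lower the number as far with a plain benzyl or a methyl on the amide nitrogen in place of the 4-methoxybenzyl group.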